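Chloro addition on the aryl amide of compound 2

The source may report more compounds than this note shows. Statements on the series, on what has been measured and on what is new or still open speak of the compounds shown alone.

Measured in a functional assay on SK-MEL-5 cells (Homo sapiens) for inhibition, read by sulforhodamine B assay, with a stated time of 48 h; a higher number here means a weaker inhibitor of growth, a lower number a stronger inhibitor of growth:
compound 1, `COc1cc(-c2nn(-c3cccc(NC(=O)Nc4cc(C(F)(F)F)cc(C(F)(F)F)c4)c3)cc2-c2ccncc2)ccc1Cl`, gives 1360 nM
compound 2, `COc1cc(-c2nn(-c3cccc(NC(=O)c4cccc(C(F)(F)F)c4)c3)cc2-c2ccncc2)ccc1Cl`, gives 2470 nM

Compound 2 holds the higher of the two numbers shown, but the gap to compound 1 is within the scatter of repeated measurements, so no order between the two can be drawn from these values. Among the compounds with values here, the two compounds do not differ in one place only, so no computed step connects them.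

Compound 3, `COc1cc(-c2nn(-c3cccc(NC(=O)c4ccc(Cl)c(C(F)(F)F)c4)c3)cc2-c2ccncc2)ccc1Cl`, is not yet measured. It differs from compound 2 by chloro in place of hydrogen on an aromatic carbon. Within the data shown here, no measured step of this kind exists to lean on. The expected step of a 1.5-fold lower number from compound 2 to compound 3 (0.19 log units; within the scatter) is no larger than the scatter, with a slight lean toward a lower number. Compound 3 is therefore estimated at 1600 nM, with a range from 600 nM to 4500 nM.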

Compound 3, concentration for total growth inhibition: 6870 nM
Compound 3: the middle estimate sits 4.3-fold (0.63 log units) below what was measured; measured number outside the range, above it.
By their numbers in this assay, from the lowest: compounds 1 and 2 (each within the scatter of the next); then compound 3.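

In this assay, chloro in place of hydrogen on the aromatic carbon ortho to a trifluoromethyl group and para to a large group gives a 2.8-fold higher number from compound 2 to compound 3 (0.44 log units; beyond the scatter). Within the data shown here, this modest step is the first single-place change, and it lies beyond the scatter: at this position on the aryl amide, one added chlorine atom, with no hydrogen-bond donor or acceptor, goes with weaker growth inhibition in this one pair. Nothing at hand explains the step.

As far as these compounds go, whether fluoro, a methyl group or an amine on the same carbon would shift the number in the same direction stays open. A single pair also cannot show whether chloro would have the same effect on the aryl group of compound 1.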